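This account rests on a few compounds, and the source may have more. Where it says the series, first, only, none or still open, it means among the compounds named here.

Measured compounds:
- Compound 1, `O=S(=O)(NC1=NCCN1C(=S)SN1CCn2c1nsc2=S)c1ccc(Cl)cc1Cl`: in a functional assay on KYSE-510 cells (Homo sapiens) for antiproliferative activity, read by crystal violet staining, with a stated time of 96 h (a higher number here means a weaker inhibitor of growth, a lower number a stronger inhibitor of growth), compound 1 gives >= 20000 nM, which is a limit of the assay and not a number.
- Compound 2, `O=S(=O)(NC1=NCCN1C(=S)SN1CCn2c1nsc2=S)c1cc(Cl)cc(Cl)c1`: in this assay compound 2 gives >= 20000 nM, again a limit of the assay rather than a number.

Compound 2 therefore stands at the edge of what this assay can report, and no potency inside the measurable range is known for it; both values shown sit at the limit of >= 20000 nM in this assay, at which 2 of the 2 values shown sit. Among the measured compounds shown here, the only measured step, a step that the two limits leave unreadable from compound 1 to compound 2, cannot be read because both of its ends rest at the limit of >= 20000 nM in this assay, at which 2 of the 2 values shown sit.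

Compound 3, `O=S(=O)(NC1=NCCN1C(=S)SN1CCn2c1nsc2=S)c1ccc(Cl)c(Cl)c1Cl`, arises from compound 2 by the change (2,3,4-trichlorophenyl in place of 3,5-dichlorophenyl on a sulfonyl sulfur). For the measured compounds named here, no measured step bears on this change, so there is no basis for expecting a shift beyond the scatter in either direction; the expectation is simply that compound 3 stays where compound 2 stands. The expected step is a step that the limit leaves unreadable from compound 2 to compound 3. Compound 3 is estimated at 25000 nM, within 8000 nM to 80000 nM, most likely reported again only as a limit.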

Compound 3, concentration for 50% growth inhibition: >= 20000 nM
Compound 3: a limit, no number; the forecaster's own chance of this, stated with the estimate: 75%; the middle value lies beyond the limit too.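

In this assay compound 3 gives >= 20000 nM as a limit and not a number. Among the compounds shown here, no step among compound 1, compound 2 and compound 3 can therefore be read: the limit of >= 20000 nM in this assay, at which 3 of the 3 values shown sit. Going by these compounds, what remains open is how strongly any of these three compounds inhibits growth, and whether the chlorine pattern on the phenyl ring matters.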